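Methoxy in place of hydrogen on compound 2

This account rests on a few compounds, and the source may have more. Where it says the series, first, only, none or still open, it means among the compounds named here.

compound 1 `CCCCCCOc1ncc(-c2ccccc2OC)n1C` gives 58000 nM
compound 2 `C=CCCCCOc1ncc(-c2ccccc2OC)n1C` gives 5000 nM
compound 3 `C=CCCCCOc1ncc(-c2cc(Cl)ccc2OC)n1C` gives 48000 nM
compound 4 `C=CCCCCOc1ncc(-c2cccc(OC)c2OC)n1C` is not yet measured

All three values come from a functional assay on T98G cells (Homo sapiens) for inhibition, read by colorimetric assay and MTT assay, with a stated time of 72 h (a lower number here means a stronger inhibitor, a higher number a weaker inhibitor), and compound 2 has the lowest number of the three at 5000 nM in this set. Compound 4 differs from compound 2 by one change (methoxy in place of hydrogen on an aromatic carbon) on an aromatic carbon. Among the measured compounds shown here, the closest precedent is chloro in place of hydrogen on an aromatic carbon, which gave a 9.6-fold higher number from compound 2 to compound 3 (0.98 log units; beyond the scatter) and is the only measured change on that ring. The step of a 12-fold lower number from compound 1 to compound 2 (1.06 log units; beyond the scatter) lies in the chain, which compound 4 leaves unchanged, so it bears little. One precedent with a different group is thin, so a rise of similar or smaller size is expected. The expected step in this assay is a 3.0-fold higher number from compound 2 to compound 4 (0.48 log units; beyond the scatter) and points to a higher number. The estimate for compound 4 is 15000 nM (expected range 3000 nM to 60000 nM).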

Compound 4, half-maximal inhibitory concentration: 35000 nM
Compound 4: the middle estimate sits 2.3-fold (0.37 log units) below what was measured; the range from low to high includes it.
By their numbers in this assay, from the lowest: compound 2; then compounds 4, 3 and 1 (each within the scatter of the next).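

In this assay, methoxy ortho to a methoxy group and meta to a large group gives a 7.0-fold higher number from compound 2 to compound 4 (0.85 log units; beyond the scatter), so this carbon of the aromatic ring does not take the added group without loss. With chloro in compound 3 on a different aromatic carbon, two different groups on this ring now both raise the number, and neither matches compound 2, which has hydrogen at both carbons. Nothing available here accounts for the rise.

On these data alone, whether fluoro, hydroxy or an amine at this carbon would also raise the number stays open. So does whether methoxy has the same effect with the saturated chain of compound 1.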